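This account rests on a few compounds, and the source may have more. Where it says the series, first, only, none or still open, it means among the compounds named here.

In a functional assay on the whole organism (strain Wister albino) for inhibition, with Rattus norvegicus as the target, read by paw edema, with stated times of 1 h and 2 h, at a dose of 50 mg/kg by the intraperitoneal route (on this read-out lower numbers stand for less inhibition and higher numbers for more inhibition at the one dose given (going by the name of the read-out)), compound 1 `CN1C(=O)[C@@]2(c3ccccc31)N(C)C[C@@H](c1ccc(Cl)cc1)[C@@]21Cc2ccccc2C1=O` gives 36.3%. Exchanging one group on its outer aromatic ring, the step of a number 28.3 percentage points lower from compound 1 to compound 2 (beyond the scatter), leads to compound 2 `Cc1ccc([C@@H]2CN(C)[C@]3(C(=O)N(C)c4ccccc43)[C@]23Cc2ccccc2C3=O)cc1`, which in this assay gives 8%. Within the data shown here, on the two numbers in hand compound 2 stands lowest; compound 1 is the only other measured compound and sits higher by a margin that is beyond the scatter.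

The next compound, compound 3 `COc1ccc([C@@H]2CN(C)[C@]3(C(=O)N(C)c4ccccc43)[C@]23Cc2ccccc2C3=O)cc1`, differs from compound 2 at the same place: methoxy in place of methyl on an aromatic carbon. Among the measured compounds shown here, no measured step covers this exact exchange, so the only guide is the one step that exists, from compound 1 to compound 2, which changed the group at this position and moved the inhibition by a modest amount. Since that single step is all there is, and it concerns a different pair of groups, the change from compound 2 to compound 3 is expected to be small, most likely an upward movement of the order of a number 10 percentage points higher from compound 2 to compound 3 (within the scatter), with a wide margin of doubt. Compound 3 is therefore estimated to give 18% in this assay, with a likely range from 2% to 40%.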

Compound 3, a percentage reported as inhibition, in the whole organism at one dose (the size of the read-out at that dose, not a potency): 20.2%
The estimate for compound 3 lay 2.2 percentage points below the measured number; the measured number falls inside the stated range.
By their numbers in this assay, from the lowest: compound 2; then compound 3; then compound 1.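

In this assay the position on the aromatic carbon, para to a large group, now has three groups to compare, and the result is more than a simple split into a high and a low compound. The new compound lies clearly between the other two: there is a rise of a number 12.2 percentage points higher from compound 2 to compound 3 (beyond the scatter) and a fall of a number 16.1 percentage points lower from compound 1 to compound 3 (beyond the scatter), and both steps are beyond the usual scatter. The exchange of methyl for methoxy adds only one heavy atom, an oxygen counted as a hydrogen-bond acceptor, yet even this small difference in the group's make-up is enough to shift the read-out, though no measurement here explains why the three groups fall in this order.

The compounds shown carry only chloro, methyl or methoxy at this place, so it remains open how an amine, a carboxylic acid or a longer chain such as ethoxy would behave there. Going by these compounds, it also remains open whether the same order of these three groups would hold at other doses, since each compound has a reading at only one dose.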